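Methylsulfonyl in Place of Chloro: Expected Cytotoxicity

The compounds below may be only part of what the source reports. "The series", "measured", "known", "first", "only" and "open" are said of these compounds alone.

Compound 1 `NCC(O)CNc1cc(N2CCCc3ccccc3C2)nc2ccccc12` gives 21000 nM in an ADME assay on HEp-2 cells (Homo sapiens) for cytotoxicity, read by CCK-8 assay, with a stated time of 5 days; on this read-out higher numbers stand for lower toxicity in this test and lower numbers for higher toxicity in this test.
Compound 3 `NCCNc1cc(N2CCCc3ccccc3C2)nc2cc(Cl)ccc12` gives 7500 nM in this assay.
Compound 2 `NCCNc1cc(N2CCCc3ccccc3C2)nc2ccc(Cl)cc12` gives > 3200 nM in this assay, which is a limit of the assay and not a number.

Compound 2 thus stands at the limit of > 3200 nM in this assay, at which 1 of the 3 values shown sits, so no exact number for it can be set against compounds 1 and 3. Compound 4 `CS(=O)(=O)c1ccc2nc(N3CCCc4ccccc4C3)cc(NCCN)c2c1` differs from compound 2 by methylsulfonyl in place of chloro on an aromatic carbon. For the measured compounds named here, no step between measured compounds is recorded, so this change has no measured counterpart here. The step that the limit leaves unreadable from compound 2 to compound 4 is expected to be small. The limit for compound 2 leaves its direction open. Compound 4 in this assay is estimated at 15000 nM, with a range from 4000 nM to 50000 nM.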

Compound 4, half-maximal cytotoxic concentration: 13000 nM
Estimate against measurement, compound 4: 1.2-fold (0.06 log units) above, within the range that was stated.
By their numbers in this assay, from the lowest: compounds 3, 4 and 1 (each within the scatter of the next, the first and the last beyond it).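

For the compounds shown here, no step from compound 2 to compound 4 can be read in this assay, because compound 2 stands only at a limit of the assay: the limit of > 3200 nM in this assay, at which 1 of the 4 values shown sits. The compounds shown leave open how large a step methylsulfonyl in place of chloro on an aromatic carbon gives.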